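Fluoro to Methoxy: Expecting the Next Antiproliferative Number

The source may hold more compounds than are shown below. What is called first, only, known or untested is meant among the compounds shown, and "the series" means these compounds.

Three compounds have so far been tested in a functional assay on A549 cells (Homo sapiens) for antiproliferative activity, read by MTT assay, with a stated time of 12 h; on this read-out higher numbers stand for weaker inhibition and lower numbers for stronger inhibition:

Compound 1, `COc1cc(OC)c2c(=O)cc(/C=C/c3ccncc3)oc2c1`, gives > 40000 nM, which is a limit of the assay rather than a number.
Compound 2, `COc1cc(OC)c2c(=O)cc(/C=C/c3ccc(C(F)(F)F)cc3)oc2c1`, gives > 40000 nM, again a limit.
Compound 3, `COc1cc(OC)c2c(=O)cc(/C=C/c3ccc(F)cc3)oc2c1`, gives 18600 nM.

Going by the values given here, compound 3 therefore holds the only measured number; the other two sit at the limit of > 40000 nM in this assay, at which 2 of the 3 values shown sit. Both steps that lead to it point the same way: an at least 2.1-fold lower number from compound 1 to compound 3 (0.33 log units; beyond the scatter) and an at least 2.1-fold lower number from compound 2 to compound 3 (0.33 log units; beyond the scatter). The next compound, compound 4, `COc1ccc(/C=C/c2cc(=O)c3c(OC)cc(OC)cc3o2)cc1`, carries methoxy in place of fluoro on an aromatic carbon. Among the compounds with values here, of the measured steps, only the one from compound 2 to compound 3 changes the same position, and it was at least modest in size. Within the data shown here, no step yet covers a methoxy group, so the direction is uncertain, and the scatter of this read-out is wide. Compound 4 is expected to stay close to compound 3, with a 1.2-fold lower number from compound 3 to compound 4 (0.09 log units; within the scatter), giving an estimated 15000 nM within 4000 nM to 40000 nM.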

Compound 4, half-maximal inhibitory concentration: > 40000 nM
Compound 4: no number, only a limit; the forecaster's own chance of this, stated with the estimate: 25%; at least 2.6-fold (0.42 log units) between middle value and limit.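

In this assay, methoxy in place of fluoro on this aromatic carbon gives an at least 2.1-fold higher number from compound 3 to compound 4 (0.33 log units; beyond the scatter), so exchanging one small group here is enough to move the read-out beyond the scatter. Trifluoromethyl and methoxy, two quite different replacements for fluoro at this position, now both leave the compounds without a measured number. Compound 3 remains the only one of the four with a number, and the other three share a single limit: the limit of > 40000 nM in this assay, at which 3 of the 4 values shown sit.

The steps from compound 1 and compound 2 to compound 4 cannot be read, since both ends of each are limits. Left open are how far compound 4 lies past its limit and whether a chloro group or an amine on this aromatic carbon would give a number, and on which side of compound 3 it would fall.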